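The source may hold more compounds than are shown below. What is called first, only, known or untested is meant among the compounds shown, and "the series" means these compounds.

Measured in a physicochemical assay for solubility, read by spectrophotometry, at pH 6.8; a higher number here means a more soluble compound, a lower number a less soluble compound:
- compound 1 `N#Cc1ccc(N[C@H]2CC[C@H](N(C(=O)NCc3ccccc3)c3ccccc3)CC2)nc1`: 4 ug/mL
- compound 2 `N#Cc1ccc(N[C@H]2CC[C@H](N(C(=O)NCc3ccccc3)c3ccc(-c4cccnc4)cc3)CC2)nc1`: 0.67 ug/mL
- compound 3 `Cn1ccc(-c2ccc(N(C(=O)NCc3ccccc3)[C@H]3CC[C@H](Nc4ccc(C#N)cn4)CC3)cc2)cc1=O`: not yet measured

Going by the values given here, compound 1 holds the highest of the two numbers so far. Compound 3 differs from it by a group of 8 heavy atoms (6 carbon, 1 nitrogen, 1 oxygen; one six-membered aromatic ring with 1 hetero atom) in place of a hydrogen atom, on an aromatic carbon, para to a large group. Among the compounds with values here, only one measured step bears on this change: a 6.0-fold lower number from compound 1 to compound 2 (0.78 log units; beyond the scatter), with pyridin-3-yl in place of hydrogen on an aromatic carbon. On this single precedent, a drop of similar size, beyond the scatter, is expected in this assay. The expected step is a 5.0-fold lower number from compound 1 to compound 3 (0.70 log units; beyond the scatter). Compound 3 is estimated at 0.8 ug/mL, with an expected range of 0.25 ug/mL to 2.5 ug/mL.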

Compound 3, solubility: < 0.08 ug/mL
Compound 3 was reported as a limit; the forecaster's own chance of this, stated with the estimate: 10%; middle value at least 10-fold (1.00 log units) away from the limit.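

In this assay compound 3 is read only as a limit, not as a number: the limit of < 0.08 ug/mL in this assay, at which 1 of the 3 values shown sits. With that limit, the group of 8 heavy atoms in place of hydrogen on this aromatic carbon gives an at least 50-fold lower number from compound 1 to compound 3 (1.69 log units; beyond the scatter), so the step seen with pyridin-3-yl does not mark how low this position can go. The two rings are not interchangeable here, as the change from pyridin-3-yl to the group of 8 heavy atoms gives an at least 8.3-fold lower number from compound 2 to compound 3 (0.92 log units; beyond the scatter).

Going by these compounds, the true size of both steps stays open while compound 3 remains a limit. Also open, on these data alone, is whether a ring carrying an amine or a carboxylic acid at this position would return the number towards that of compound 1.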